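The source may hold more compounds than are shown below. What is called first, only, known or untested is meant among the compounds shown, and "the series" means these compounds.

Among the measured compounds shown here, compound 2 `CC(C)(C)c1ccc(C2=C(/C=N/O)CCC2)cc1` holds the lower of the two numbers so far: in an assay on HEK293T cells for inhibition of fibroblast growth factor 23 (Homo sapiens), read by a luciferase reporter, with a stated time of 5 h (a higher number here means a weaker inhibitor, a lower number a stronger inhibitor), compound 2 gives 2790 nM, while compound 1 `O/N=C/C1=C(c2ccccc2)CCC1` gives 10000 nM. For the measured compounds named here, the one measured step, a 3.6-fold lower number from compound 1 to compound 2 (0.55 log units; beyond the scatter), is the only guide to that aromatic carbon. Compound 3 `COc1ccc(C2=C(/C=N/O)CCC2)cc1` differs from compound 2 by methoxy in place of tert-butyl on an aromatic carbon. Because a 3.6-fold lower number from compound 1 to compound 2 (0.55 log units; beyond the scatter) was modest, compound 3 is expected to give back part of that change, a rise in this assay of a 1.8-fold higher number from compound 2 to compound 3 (0.25 log units; within the scatter). Compound 3 is estimated at 5000 nM, with a range from 2000 nM to 12000 nM.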

Compound 3, half-maximal inhibitory concentration: 12300 nM
For compound 3 the middle estimate is 2.5-fold (0.39 log units) below the measured one, and the stated range ends below it.
By their numbers in this assay, from the lowest: compound 2; then compounds 1 and 3 (each within the scatter of the next).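

In this assay, the lower number at this aromatic carbon does not extend to methoxy: methoxy in place of tert-butyl gives a 4.4-fold higher number from compound 2 to compound 3 (0.64 log units; beyond the scatter). Methoxy in place of hydrogen gives a 1.2-fold higher number from compound 1 to compound 3 (0.09 log units; within the scatter), so methoxy does not separate from hydrogen here, and among these three compounds only tert-butyl lowers the number. Nothing available explains this difference between the two groups. As far as these compounds go, it remains open whether an amine, a trifluoromethyl group or a longer chain at this carbon would behave like tert-butyl or like methoxy.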